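The source may hold more compounds than are shown below. What is called first, only, known or untested is meant among the compounds shown, and "the series" means these compounds.

Measured so far:
- compound 1 `CC(C(=O)NCc1ccc(C(F)(F)F)nc1)c1ccc(NS(C)(=O)=O)c(F)c1` — in a functional assay on CHO-K1 cells for antagonist activity at transient receptor potential cation channel subfamily V member 1 (Homo sapiens), read by FLIPR (on this read-out lower numbers stand for stronger inhibition and higher numbers for weaker inhibition), compound 1 gives "not active" (no number reported)
- compound 2 `CC1CCC(Nc2nc(C(F)(F)F)ccc2CNC(=O)C(C)c2ccc(NS(C)(=O)=O)c(F)c2)CC1` — in this assay compound 2 gives 1130 nM

Among the measured compounds shown here, compound 1 stands without a number in this assay: it is recorded only as inactive, so it cannot be placed on the scale next to compound 2, the only measured compound with a numerical value. For the measured compounds named here, no pair of measured compounds differs in a single place, so no measured step is available.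

Compound 3 `Cc1ccc(Nc2nc(C(F)(F)F)ccc2CNC(=O)C(C)c2ccc(NS(C)(=O)=O)c(F)c2)cc1C` is the unmeasured member. It differs from compound 1 as (3,4-dimethylphenyl)amino in place of hydrogen on an aromatic carbon.

Expectation: the change from compound 1 to compound 3 is expected to move this assay toward stronger inhibition, well beyond the scatter, because compound 2 gives 1130 nM while compound 1, which lacks such an additional substituent on the shared core, gave no measurable number. Compound 3 is therefore estimated to come out near 600 nM in this assay, with a range of roughly 150 nM to 2500 nM. A limit rather than a number is considered unlikely for compound 3.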

Compound 3, half-maximal inhibitory concentration: 1160 nM
Estimate against measurement, compound 3: 1.9-fold (0.29 log units) below, within the range that was stated.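

In this assay, 3,4-dimethylphenyl in place of 4-methylcyclohexyl on the nitrogen gives a 1.0-fold higher number from compound 2 to compound 3 (0.01 log units; within the scatter) and so separates the two groups by no more than the usual scatter: at this aromatic carbon next to the ring nitrogen, the amino substituent can carry a six-membered aromatic ring of carbon only or 4-methylcyclohexyl with no readable difference. With hydrogen on this carbon, compound 1 gives "not active" (no number reported) on the same read-out, whereas both amino-substituted compounds give numbers, so measurable inhibition in these compounds now appears with two different groups on the nitrogen, although compound 1 offers no number from which to size the gain. No measured information available here accounts for either observation.

Still open, from the compounds shown here alone, is how far this tolerance extends to smaller or more flexible amino groups, such as methylamino or butylamino, and to an unsubstituted phenylamino group, which would address the two methyl groups on the aromatic ring. Also open, going by these compounds, is whether the nitrogen link itself matters, a question that phenoxy, with oxygen in its place, or a phenyl group bonded directly to the aromatic carbon could answer.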